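The source may hold more compounds than are shown below. What is called first, only, known or untested is meant among the compounds shown, and "the series" means these compounds.

Compound 1 `O=S(=O)(c1cc(F)cc(F)c1)c1cnc2cc(F)ccc2c1-c1cccc(F)c1` has the lower of the two numbers recorded in an ADME assay on microsomes from liver (Homo sapiens) for metabolic stability, tested at 2.5 uM; a higher number here means faster removal of the compound, a lower number slower removal: compound 1 gives 0.06 mL/min. Among the compounds with values here, its only measured neighbour is compound 2 `O=S(=O)(c1cc(F)cc(F)c1)c1cnc2cc(F)ccc2c1-c1cccc(Cl)c1`, which gives 0.22 mL/min in this assay; the step of a 3.7-fold higher number from compound 1 to compound 2 (0.56 log units; beyond the scatter).

Compound 3 `Cc1ccc(S(=O)(=O)c2cnc3cc(F)ccc3c2-c2cccc(F)c2)cc1F` differs from compound 1 in another place. The change is 3-fluoro-4-methylphenyl in place of 3,5-difluorophenyl on a sulfonyl sulfur. Within the data shown here, no measured step changes the group on the sulfonyl sulfur, so there is no direct comparison to lean on. Among the measured compounds shown here, the one measured step, from compound 1 to compound 2, swaps a single halogen on a different aromatic ring, and it moved the number upward by a modest amount that was beyond the scatter. For the measured compounds named here, that step is the only guide to how much a small change on an aromatic ring can shift this read-out.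

Taking that as the scale, compound 3 is expected to move by a 2.5-fold higher number from compound 1 to compound 3 (0.40 log units; beyond the scatter), an upward step of modest size. The estimate for compound 3 in this assay is 0.15 mL/min, with a likely range from 0.06 mL/min to 0.4 mL/min.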

Compound 3, intrinsic clearance in a liver preparation (reported as CLH), per the amount of preparation that the assay uses: 0.41 mL/min
The estimate for compound 3 lay 2.7-fold (0.44 log units) below the measured number; the whole stated range lies below it.
By their numbers in this assay, from the lowest: compound 1; then compounds 2 and 3 (each within the scatter of the next).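

In this assay, the group on the sulfonyl sulfur turns out to matter as well: 3-fluoro-4-methylphenyl in place of 3,5-difluorophenyl gives a 6.8-fold higher number from compound 1 to compound 3 (0.83 log units; beyond the scatter). Within the data shown here, until now, the only measured change was a halogen swap on a different aromatic ring, so this is the first sign that the read-out also responds at this second place in the molecule, and again the number goes up. The shift appears even though the two groups have the same count of heavy atoms, each is a single six-membered aromatic ring of carbon only, and neither carries a hydrogen-bond donor or acceptor or a net charge, and nothing shown explains the rise.

This change removes one fluorine and adds a methyl group in a single step, so the compounds shown cannot tell how much of the rise belongs to each part. Also open, as far as these compounds go, is how the number would respond if the ring on the sulfonyl sulfur carried a methoxy group or an amine, or if that ring were replaced by a pyridine.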